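From Ethoxyphenyl to Ethyl-Methylphenyl on an Aromatic Nitrogen

The source may hold more compounds than are shown below. What is called first, only, known or untested is meant among the compounds shown, and "the series" means these compounds.

In a functional assay on A549 cells (Homo sapiens) for antiproliferative activity, read by MTT assay, with a stated time of 48 h (on this read-out lower numbers stand for stronger inhibition and higher numbers for weaker inhibition), three compounds sharing one core have been measured.
Compound 1 `N#CC1=C(N)Oc2c(N)cc3nc4ccccc4nc3c2C12C(=O)N(Cc1cnnn1-c1cccc(C(F)(F)F)c1)c1ccccc12` gives 5400 nM.
Compound 2 `CCOc1ccc(-n2nncc2CN2C(=O)C3(C(C#N)=C(N)Oc4c(N)cc5nc6ccccc6nc5c43)c3ccccc32)cc1` reaches only the assay's limit, > 50000 nM.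
Compound 3 `CCOc1ccccc1-n1nncc1CN1C(=O)C2(C(C#N)=C(N)Oc3c(N)cc4nc5ccccc5nc4c32)c2ccccc21` likewise reaches only the assay's limit, > 50000 nM.

Compound 3 thus stands at a limit, not a number, and shares it with compound 2 (the limit of > 50000 nM in this assay, at which 2 of the 3 values shown sit). Going by the values given here, the one real number comes from compound 1; the step of an at least 9.2-fold higher number from compound 1 to compound 3 (0.96 log units; beyond the scatter) lies beyond the scatter, as does an at least 9.2-fold higher number from compound 1 to compound 2 (0.96 log units; beyond the scatter). The step that the two limits leave unreadable from compound 2 to compound 3 stays unreadable. Compound 4 `CCc1cccc(C)c1-n1nncc1CN1C(=O)C2(C(C#N)=C(N)Oc3c(N)cc4nc5ccccc5nc4c32)c2ccccc21` carries the change (2-ethyl-6-methylphenyl in place of 2-ethoxyphenyl on an aromatic nitrogen). Among the compounds with values here, no measured step tests this swap directly; the readable steps only show that the group on this aromatic nitrogen can move the number by at least a modest amount. The step of an at least 1.2-fold lower number from compound 3 to compound 4 (0.09 log units; that floor lies within the scatter) is therefore expected to stay within the scatter, with a fair chance of another limit. Compound 4 is estimated at 40000 nM, between 8000 nM and 150000 nM.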

Compound 4, half-maximal inhibitory concentration: > 50000 nM
Compound 4: only a limit was reported; the forecaster's own chance of this, stated with the estimate: 55%; at least 1.2-fold (0.09 log units) between middle value and limit.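

In this assay compound 4 also stops at a limit, not a number, so a 2-ethyl-6-methylphenyl group, with no oxygen, gives no readable gain over 2-ethoxyphenyl: the limit of > 50000 nM in this assay, at which 3 of the 4 values shown sit. The steps to compound 4 from compound 2 and from compound 3 cannot be read, as both ends of each are limits. Going by these compounds alone, the one readable new step is an at least 9.2-fold higher number from compound 1 to compound 4 (0.96 log units; beyond the scatter), which leaves compound 1, with its 3-(trifluoromethyl)phenyl, as the only compound here with a real number. Still open, going by these compounds, is how a phenyl ring carrying an amine or a carboxylic acid would read on this nitrogen.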